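Series notes: the step from compound 2 to compound 4

A few compounds are considered here, and "the series" means these few. Any claim that something is new, unique, unknown or untested is made for them only; others in the source may bear on it.

Values in a physicochemical assay for lipophilicity, read by HPLC; on this read-out lower numbers stand for lower lipophilicity and higher numbers for higher lipophilicity:
- compound 1 `COC(=O)C1(c2ccc(NC(=O)Nc3cccnc3Oc3ccccc3C(C)(C)C)cc2)CC1`: 5.1
- compound 2 `CC(C)(C)c1ccccc1Oc1ncccc1NC(=O)Nc1ccc(-c2ccccc2CO)cc1F`: 5.5
- compound 3 `CC(C)(C)c1ccccc1Oc1ncccc1NC(=O)Nc1ccc(N2CCCCC2)cc1`: 5.5
- compound 4 `CN(C)Cc1cccc(-c2ccc(NC(=O)Nc3cccnc3Oc3ccccc3C(C)(C)C)c(F)c2)c1`: not yet measured

In this assay, compound 2 gives 5.5, level with compound 3 at 5.5. These two share the highest of the three numbers, and compound 1 lies lower at 5.1.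

The change under consideration is 3-((dimethylamino)methyl)phenyl in place of 2-(hydroxymethyl)phenyl on an aromatic carbon. In words, 3-((dimethylamino)methyl)phenyl stands in place of 2-(hydroxymethyl)phenyl, on an aromatic carbon meta to a fluoro group and para to a large group.

Within the data shown here, no measured step covers this exchange. Among the measured compounds shown here, the only step available is a number 0.40 log units higher from compound 1 to compound 3 (beyond the scatter), a modest one, with piperidin-1-yl in place of 1-(methoxycarbonyl)cyclopropyl on an aromatic carbon. It bears on the question only loosely, as a guide to how far a change of group has moved the number in this small set. Compound 2 at 5.5 already shares the top of the range, so a step no larger than that modest one, and downward, is the working expectation, held with little confidence. The expected step is a number 0.30 log units lower from compound 2 to compound 4 (within the scatter). Compound 4 is estimated at 5.2. The expected range runs from 4.6 to 5.7.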

Compound 4, partition coefficient: 5.5
The estimate for compound 4 lay 0.30 log units below the measured number, within the range that was stated.
By their numbers in this assay, from the lowest: compound 1; then compounds 2, 3 and 4 (each within the scatter of the next).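

At this aromatic carbon, meta to a fluoro group and para to a large group, this assay shows no change at the digits printed from compound 2 to compound 4 (within the scatter) when 3-((dimethylamino)methyl)phenyl stands in place of 2-(hydroxymethyl)phenyl. The earlier compounds shown here offered no pair varying the group within this biaryl-type substituent, and this pair shows that the read-out can stay level across a change from 8 to 10 heavy atoms, from oxygen to nitrogen, and from 1 hydrogen-bond donor to 0. No evidence at hand bears on why the number holds level.

The exchange alters both the group and where it sits on the phenyl ring, so this single pair cannot separate the two changes; a compound carrying 3-(hydroxymethyl)phenyl or 2-((dimethylamino)methyl)phenyl at this carbon would divide them. Going by these compounds, whether the level reading would extend to a carboxylic acid on the same phenyl ring, or to a longer chain ending in an amine, remains open.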